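Swapping the chlorophenyl amide partner for a pyridinyl group

The source may hold more compounds than are shown below. What is called first, only, known or untested is meant among the compounds shown, and "the series" means these compounds.

Measured compounds:
compound 1, `CCC(=O)Nc1cc(C(=O)Nc2cccc(Cl)c2)ccc1OC`: 602 uM
compound 2, `CCC(=O)Nc1cc(C(=O)Nc2ccc([N+](=O)[O-])cc2)ccc1OC`: 307 uM

Of the compounds shown here, two sharing the same core have been measured in an ADME assay on MDCK cells (Canis lupus familiaris) for cytotoxicity, read by cytopathic effect, with a stated time of 48 h; a higher number here means that more compound is tolerated, a lower number that less compound is tolerated. Compound 1 gives 602 uM, the higher of the two numbers. Compound 2 gives 307 uM in this assay; the gap between compound 1 and compound 2 lies within the usual scatter of repeated measurements, so the two values cannot be told apart, and neither compound can be called better tolerated than the other.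

Compound 3, `CCC(=O)Nc1cc(C(=O)Nc2ccccn2)ccc1OC`, has not yet been measured in this assay. It differs from compound 1 in one place: pyridin-2-yl in place of 3-chlorophenyl on an amide-type nitrogen. Among the measured compounds shown here, no comparable step between measured compounds exists in this set, so nothing measured indicates how large a change to expect from this replacement.

On that basis the tolerated concentration of compound 3 is expected to stay close to that of compound 1. The expected step is a 1.1-fold higher number from compound 1 to compound 3 (0.03 log units; within the scatter), which would not exceed the scatter. Compound 3 is estimated at 650 uM, with a range from 280 uM to 1500 uM.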

Compound 3, half-maximal toxic concentration: > 668 uM
Compound 3: only a limit was reported (the forecaster's own chance of this, stated with the estimate: 30%); middle value at least 1.0-fold (0.01 log units) from the limit.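

Among the compounds shown here, this is the first step that can be read at the amide-type nitrogen: in this assay, pyridin-2-yl in place of 3-chlorophenyl gives an at least 1.1-fold higher number from compound 1 to compound 3 (0.04 log units; that floor lies within the scatter), so a six-membered aromatic ring with a hetero atom is accepted at this place with no sign of a loss in tolerated concentration. The reading for compound 3 is a limit and not a number: the limit of > 668 uM in this assay, at which 1 of the 3 values shown sits. The step therefore has only a floor, and as that floor lies within the scatter, it shows that this replacement brings no measurable cost here, not that the tolerated concentration has risen.

Going by these compounds, how far the tolerated concentration of compound 3 reaches past its limit remains open, and with it whether the replacement brings any real rise at all. Also open, on these data alone, is whether the same tolerance would hold for other groups on this amide-type nitrogen, such as pyridin-3-yl, a saturated piperidinyl ring, or a phenyl ring carrying an amine or a carboxylic acid.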